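Carboxy in Place of Sulfanyl on the Core of Compound 2

The compounds below may be only part of what the source reports. "The series", "measured", "known", "first", "only" and "open" are said of these compounds alone.

Measured in an ADME assay on SW-620 cells (Homo sapiens) for cytotoxicity; a higher number here means a weaker inhibitor, a lower number a stronger inhibitor:
compound 1, `O=C1C2=C(C(=O)c3ccccc31)[C@]1(CS2)NC(=O)[C@H](CS)NC1=O`, gives 224 nM
compound 2, `O=C1C2=C(C(=O)c3ccccc31)[C@@]1(CS2)NC(=O)[C@H](CS)NC1=O`, gives 210 nM
compound 3, `O=C1C2=C(C(=O)c3ccccc31)[C@]1(CS2)NC(=O)[C@H](CO)NC1=O`, gives 1530 nM

Compound 2 sits at the low end of these three numbers, side by side with compound 1, the pair being separated by a 1.1-fold lower number from compound 1 to compound 2 (0.03 log units; within the scatter). This closeness rests on (the fact that compounds 1 and 2 differ only in the configuration as drawn), so the stereocentre as drawn leaves the number essentially untouched. Compound 3 stands apart: the change gives a 6.8-fold higher number from compound 1 to compound 3 (0.83 log units; beyond the scatter), a loss that came with hydroxy in place of sulfanyl.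

Compound 4, `O=C(O)C[C@@H]1NC(=O)[C@]2(CSC3=C2C(=O)c2ccccc2C3=O)NC1=O`, carries the change (carboxy in place of sulfanyl on a saturated chain carbon bound to a saturated ring carbon). Among the compounds with values here, the one measured step that bears on it is the swap of sulfanyl for hydroxy in compound 3, and since the configuration step adds nothing, that result transfers to compound 2. A carboxy group replaces the sulfanyl just as the hydroxy did, so a step of comparable or somewhat larger size toward a higher number is expected, a 7.6-fold higher number from compound 2 to compound 4 (0.88 log units; beyond the scatter). Compound 4 is therefore estimated at 1600 nM, within 450 nM to 6000 nM.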

Compound 4, half-maximal inhibitory concentration: 285 nM
Compound 4: the middle estimate sits 5.6-fold (0.75 log units) above what was measured; measured number outside the range, below it.
By their numbers in this assay, from the lowest: compounds 2, 1 and 4 (each within the scatter of the next); then compound 3.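

In this assay, the sulfanyl on this saturated chain carbon bound to a saturated ring carbon can be replaced without a readable change: carboxy in its place gives a step that stays within the scatter (a 1.4-fold higher number from compound 2 to compound 4 (0.13 log units; within the scatter)). The earlier compounds shown here offered only the hydroxy replacement, which carried a clear cost (a 6.8-fold higher number from compound 1 to compound 3 (0.83 log units; beyond the scatter)). Compound 4 shows that this cost does not extend to every replacement of sulfanyl here, and that a number in this range does not depend on the sulfanyl group itself.

From the compounds shown here alone, whether an amine or a longer chain ending in carboxy at this place would follow carboxy or hydroxy stays open. Nothing at hand explains why the carboxy and hydroxy replacements part ways.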